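The source may hold more compounds than are shown below. What is called first, only, known or untested is meant among the compounds shown, and "the series" means these compounds.

Measured so far in a physicochemical assay for permeability, using PAMPA; a lower number here means that the compound crosses the layer more slowly, a higher number that the compound crosses the layer faster:

- compound 1, `Cc1oc(-c2c(C)c(C)c(C)c(C)c2C)nc1CN1CCC(C(=O)NCCCN2C[C@H](C)C[C@H](C)C2)CC1`: 455 10^-6 cm/s
- compound 3, `Cc1oc(-c2c(F)cccc2F)nc1CN1CCC(C(=O)NCCCN2C[C@H](C)C[C@H](C)C2)CC1`: 82.4 10^-6 cm/s
- compound 2, `Cc1ccccc1-c1nc(CN2CCC(C(=O)NCCCN3CC(C)(C)CC(C)(C)C3)CC2)c(C)o1`: in this assay compound 2 reaches only a limit, > 1390 10^-6 cm/s

Compound 2 therefore stands at the top of the numbers shown: the limit of > 1390 10^-6 cm/s in this assay, at which 1 of the 3 values shown sits, so its true value is not known, only that it lies at or past that limit. Going by the values given here, compound 1 and compound 3 give numbers, and the one step between them, a 5.5-fold lower number from compound 1 to compound 3 (0.74 log units; beyond the scatter), concerns the aromatic carbon only.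

Compound 4, `CCCN(CCC)CCNC(=O)C1CCN(Cc2nc(-c3ccccc3C)oc2C)CC1`, differs from compound 2 at the other end of the molecule: a group of 7 heavy atoms (6 carbon, 1 nitrogen; no ring) in place of a group of 11 heavy atoms (10 carbon, 1 nitrogen; one six-membered non-aromatic ring with 1 hetero atom), on a saturated chain carbon, two bonds along the chain from an amide-type nitrogen. Among the compounds with values here, no measured step touches this part of the structure, so the step from compound 1 to compound 3 does not bear on it directly; it only shows that changes of modest size can move this assay beyond the scatter. With the starting point itself a limit, the best that can be said is that compound 4 is expected to give a number in the same high region, perhaps somewhat lower, an at least 1.7-fold lower number from compound 2 to compound 4 (0.23 log units; that floor lies within the scatter). Compound 4 is therefore estimated at 800 10^-6 cm/s, within a range of 300 10^-6 cm/s to 1390 10^-6 cm/s.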

Compound 4, apparent permeability: 913 10^-6 cm/s
For compound 4 the middle estimate is 1.1-fold (0.06 log units) below the measured one; measured number inside the range.
By their numbers in this assay, from the lowest: compound 3; then compounds 1 and 4 (each within the scatter of the next). At a limit, above all of these: compound 2.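

In this assay, going by these compounds alone, compound 4 gives the first reading of a change at this end of the molecule, where dipropylamino takes the place of the ring-bearing group on a saturated chain carbon, two bonds along the chain from an amide-type nitrogen, and the step is an at least 1.5-fold lower number from compound 2 to compound 4 (0.18 log units; that floor lies within the scatter). Compound 4 has no ring in this group and still gives 913 10^-6 cm/s, so the ring of compound 2 is not required for a number of this size. As far as these compounds go, the true size of the step remains unknown, because compound 2 gives only a limit and not a number: the limit of > 1390 10^-6 cm/s in this assay, at which 1 of the 4 values shown sits.

The compounds shown do not tell whether the number would hold with a smaller amine such as dimethylamino, with a carboxylic acid or a hydroxyl group in this place, or with a longer chain leading to the amine. They also leave open whether dipropylamino would give a similar result alongside the 2,6-difluorophenyl group of compound 3, whose number is the lowest of those shown.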